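Swapping cyclopropyl for 4-methylphenyl on a sulfonamide

This account rests on a few compounds, and the source may have more. Where it says the series, first, only, none or still open, it means among the compounds named here.

Measured in an ADME assay (liver) for metabolic stability, with Liver microsome (Homo sapiens) as the target, read by LC-MS, using microsomes and NADPH, with a stated time of 5 min, at 37 degrees C; a lower number here means slower removal, a higher number faster removal of the compound:
- compound 1 `CCn1c([C@@H](C)NS(=O)(=O)c2ccc(Cl)cc2)nc2cc(F)c(Cl)cc21`: > 100 mL.min-1.g-1
- compound 2 `CCn1c(C(C)NS(=O)(=O)c2ccc(Cl)cc2)nc2ccncc21`: 93 mL.min-1.g-1
- compound 3 `CCn1c([C@@H](C)NS(=O)(=O)C2CC2)nc2ccc(C(F)(F)F)cc21`: < 3 mL.min-1.g-1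

Compound 3 stands at the slow end of these three compounds. Its < 3 mL.min-1.g-1 is a limit of the assay and not a number: the limit of < 3 mL.min-1.g-1 in this assay, at which 1 of the 3 values shown sits. The next compound, compound 4 `CCn1c([C@@H](C)NS(=O)(=O)c2ccc(C)cc2)nc2ccc(C(F)(F)F)cc21`, changes one group of compound 3: 4-methylphenyl in place of cyclopropyl on a sulfonyl sulfur. The core of compound 3 stays as it is, and 4-methylphenyl in place of cyclopropyl on a sulfonyl sulfur is the whole change.

Going by the values given here, no measured pair here isolates this kind of swap, so the guide is indirect. Compound 1 also has a six-membered aromatic ring on its sulfonyl sulfur, and its > 100 mL.min-1.g-1 is a limit too. Compound 2 has such a ring as well and gives 93 mL.min-1.g-1, a true number. Both differ from compound 3 in the core too, which weakens the comparison.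

In this assay a clear rise is therefore expected, well beyond the usual scatter, and the estimated step is an at least 13-fold higher number from compound 3 to compound 4 (1.12 log units; beyond the scatter). For compound 4 the expected value is 40 mL.min-1.g-1, with an estimated range of 12 mL.min-1.g-1 to 100 mL.min-1.g-1.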

Compound 4, intrinsic clearance in microsomes: > 100 mL.min-1.g-1
Compound 4 gave a limit, no number; the forecaster's own chance of this, stated with the estimate: 15%; middle value at least 2.5-fold (0.39 log units) away from the limit.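

Going by these compounds alone, the swap on the sulfonyl sulfur is the only change between these two compounds, so in this assay the shift of an at least 33-fold higher number from compound 3 to compound 4 (1.52 log units; beyond the scatter) belongs to this one position, with the core held fixed, which compounds 1 and 2 could not show because their cores differ too. The value of compound 4 is a limit of the assay and not a number: the limit of > 100 mL.min-1.g-1 in this assay, at which 2 of the 4 values shown sit. The value of compound 3 is also a limit and not a number: the limit of < 3 mL.min-1.g-1 in this assay, at which 1 of the 4 values shown sits.

A plain phenyl ring without the methyl, a saturated cyclohexyl ring or a short ethyl chain on the sulfonyl sulfur would help separate whether the faster removal goes with the aromatic ring, with its methyl group or simply with a larger group in place of cyclopropyl. As far as these compounds go, with a limit at both ends of the step, its true size stays unknown, and whether the same swap would have a similar effect on another core remains open as well.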